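The compounds below may be only part of what the source reports. "The series", "measured", "known", "first", "only" and "open" are said of these compounds alone.

Compound 1 `C=C(C)[C@H]1CC=C(C)[C@@]2(O)[C@@H]1[C@H](c1ccccc1Br)O[C@@H]2C(=O)OC` carries the shared core with a 2-bromophenyl group and a methoxycarbonyl group. In a functional assay on KB3 cells (Homo sapiens) for antiproliferative activity, read by MTT assay, with a stated time of 96 h (a higher number here means a weaker inhibitor, a lower number a stronger inhibitor), compound 1 gives 5000 nM. Compound 2 `C=C(C)[C@H]1CC=C(C)[C@@]2(O)[C@@H]1[C@H](c1cccc(Cl)c1Cl)O[C@@H]2C(=O)OCC` gives 5000 nM, the same number at the digits shown, so these two compounds sit together at the low end of the three measured numbers. Compound 3 `C=C(C)[C@H]1CC=C(C)[C@@]2(O)[C@@H]1[C@H](c1ccccn1)O[C@@H]2C(=O)OC` gives 100000 nM; the step of a 20-fold higher number from compound 1 to compound 3 (1.30 log units; beyond the scatter) is large and beyond the scatter.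

Compound 4 `C=C(C)[C@H]1CC=C(C)[C@@]2(O)[C@@H]1[C@H](c1ccccc1Br)O[C@@H]2C(=O)O` differs from compound 1 in one place: hydrogen in place of methyl on an oxygen next to a carbonyl group. For the measured compounds named here, none of the measured steps touches this part of the molecule. Going by the values given here, the only measured step exchanges the aromatic group on a saturated ring carbon, and compound 2 differs from compound 1 in two places at once, so it offers no single-change comparison. Among the compounds with values here, the expectation therefore rests on no direct precedent, and a wide range is appropriate. Compound 4 is expected to give a somewhat higher number than compound 1, a 3.0-fold higher number from compound 1 to compound 4 (0.48 log units; beyond the scatter), with an estimate of 15000 nM and a range from 3000 nM to 100000 nM.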

Compound 4, half-maximal inhibitory concentration: > 100000 nM
Compound 4 was reported as a limit (the forecaster's own chance of this, stated with the estimate: 25%); at least 6.6-fold (0.82 log units) between middle value and limit.
By their numbers in this assay, from the lowest: compounds 1 and 2 (each within the scatter of the next); then compound 3.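

Up to here only the aromatic group had been changed on its own, and this result shows that the methoxycarbonyl group counts as well: in this assay the change from methoxycarbonyl to carboxy gives an at least 20-fold higher number from compound 1 to compound 4 (1.30 log units; beyond the scatter) as its step. Hydrogen in place of methyl on an oxygen next to a carbonyl group removes only one heavy atom, a single carbon, and that is enough here for a large step. For compound 4, > 100000 nM is a limit of the assay and not a number, so the step marks a minimum only: the limit of > 100000 nM in this assay, at which 1 of the 4 values shown sits.

Going by these compounds, how far compound 4 lies past that limit stays open. So does whether a primary amide, or a longer chain such as a propyl ester, would hold the value of compound 1 in this place.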